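Swapping Nitro for Chloro on the Anilide of Compound 2

The source may report more compounds than this note shows. Statements on the series, on what has been measured and on what is new or still open speak of the compounds shown alone.

Compound 2, `O=C(CSc1nncnc1-c1cccc2ccccc12)Nc1ccccc1[N+](=O)[O-]`: 142000 nM
Compound 3, `O=C(CSc1nncnc1-c1ccccc1Cl)Nc1ccccc1[N+](=O)[O-]`: 63000 nM
Compound 1, `COC(=O)c1ccc(NC(=O)CSc2nncnc2-c2ccccc2Cl)c(Br)c1`: 59000 nM

All three share a core in which a sulfur-linked acetamide joins an aryl-bearing triazine to a substituted anilide, and all were tested in an ADME assay on MT4 cells (Homo sapiens) for cytotoxicity, read by MTT assay; a higher number here means that more compound is tolerated, a lower number that less compound is tolerated. Compound 2 stands highest of the three numbers. For the measured compounds named here, the only single-point step measured so far is a 2.3-fold lower number from compound 2 to compound 3 (0.35 log units; beyond the scatter), which changes the aryl group on the triazine rather than the anilide. Compound 1 and compound 3 both carry 2-chlorophenyl but differ at the anilide, and there compound 1 gives 59000 nM while compound 3 gives 63000 nM, two numbers that lie within the scatter of each other.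

Compound 4, `O=C(CSc1nncnc1-c1cccc2ccccc12)Nc1ccccc1Cl`, keeps the naphthalen-1-yl group of compound 2 and changes only the anilide: chloro in place of nitro on an aromatic carbon. Going by the values given here, no measured step touches this position, so the anilide substitution is unexplored territory; the only hint, from compound 1 and compound 3, is that a different anilide pattern left the number roughly unchanged. The expectation in this assay is therefore a step of a 1.2-fold lower number from compound 2 to compound 4 (0.07 log units; within the scatter), that is, nothing beyond the scatter. Compound 4 is estimated at 120000 nM, within a range from 55000 nM to 260000 nM.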

Compound 4, half-maximal cytotoxic concentration: 63000 nM
Beside the measured number, compound 4's estimate is 1.9-fold (0.28 log units) above it; measured number inside the range.
By their numbers in this assay, from the lowest: compounds 1, 3 and 4 (each within the scatter of the next); then compound 2.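

In this assay, the anilide position proves able to move the number: chloro in place of nitro on an aromatic carbon, ortho to a large group, gives a 2.3-fold lower number from compound 2 to compound 4 (0.35 log units; beyond the scatter), and this step matches in printed size the change of aryl group on the core, a 2.3-fold lower number from compound 2 to compound 3 (0.35 log units; beyond the scatter). The earlier pair differing at the anilide, compound 1 at 59000 nM and compound 3 at 63000 nM, lies within the scatter, so a shift at the anilide is seen so far only with naphthalen-1-yl on the core, while that pair carries 2-chlorophenyl and a different substitution pattern. Nothing measured here explains the drop in the number.

Still open, on these data alone, is whether chloro in place of nitro would give a similar step with 2-chlorophenyl on the core, since this single step comes from one aryl group only. As far as these compounds go, it is also open how a simple amine, a carboxylic acid or plain hydrogen at the same place would compare with nitro and chloro, so two groups cannot yet define a trend for this position.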